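The source may report more compounds than this note shows. Statements on the series, on what has been measured and on what is new or still open speak of the compounds shown alone.

Measured in a functional assay on A549 cells (Homo sapiens) for cytotoxicity, read by MTT assay, with a stated time of 72 h; a higher number here means a weaker inhibitor, a lower number a stronger inhibitor:
- compound 1 (`O=C(CN1CCN(c2nnc(Cc3ccncc3)c3ccccc23)CC1)Nc1cccc(Br)c1`) reads 1530 nM
- compound 2 (`Cc1ccc(F)cc1NC(=O)CN1CCN(c2nnc(Cc3ccccc3)c3ccccc23)CC1`) is reported as "not active" (no number reported)
- compound 3 (`Cc1ccc(F)cc1NC(=O)CN1CCN(c2nnc(Cc3ccncc3)c3ccccc23)CC1`) reads 38900 nM

For the measured compounds named here, compound 2 is recorded only as "not active" (no number reported) without a number, so no step can be counted from it. Compound 4 (`O=C(CN1CCN(c2nnc(Cc3ccccc3)c3ccccc23)CC1)Nc1cc(C(F)(F)F)ccc1Cl`) differs from compound 2 in one place, on an amide-type nitrogen, where 2-chloro-5-(trifluoromethyl)phenyl stands in place of 5-fluoro-2-methylphenyl (2-chloro-5-(trifluoromethyl)phenyl in place of 5-fluoro-2-methylphenyl on an amide-type nitrogen). The rest of the molecule stays the same.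

Going by the values given here, the only measured step that bears on this change is a 25-fold higher number from compound 1 to compound 3 (1.41 log units; beyond the scatter) and it is large. Among the compounds with values here, there, 5-fluoro-2-methylphenyl replaces 3-bromophenyl on the same kind of nitrogen, so the group entering in that step is the one leaving compound 2. This single pair suggests that swapping this group can move the number a long way, and here a move towards measurable, lower numbers is expected. Its size cannot be stated, since compound 2 offers no starting number. Compound 4 also keeps the rest of compound 2 rather than that of compound 1, which reads 1530 nM and so gives only a loose guide. It may still show no measurable activity. The estimated value for compound 4 is 8000 nM with an expected range of 1500 nM to 50000 nM on this reasoning.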

Compound 4, half-maximal inhibitory concentration: 89000 nM
The estimate for compound 4 lay 11-fold (1.05 log units) below the measured number; measured number above the stated range.
By their numbers in this assay, from the lowest: compound 1; then compound 3; then compound 4.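

In this assay compound 4 reads 89000 nM, but compound 2 has no number, so no step can be read between compound 2 and compound 4. No measurement shown here explains this reading. The compounds shown leave open how 2-chloro-5-(trifluoromethyl)phenyl would read on the core of compound 1.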